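Three limits and a bromo-for-methyl swap

The source may hold more compounds than are shown below. What is called first, only, known or untested is meant among the compounds shown, and "the series" means these compounds.

Compound 1 `N#CC1=C(N)Oc2c(c3nc4ccccc4nc3c3ccccc23)C12C(=O)N(Cc1cnnn1-c1ccc(Br)cc1)c1ccccc12`: in a functional assay on HepG2 cells (Homo sapiens) for antiproliferative activity, read by MTT assay, with a stated time of 48 h (a lower number here means a stronger inhibitor, a higher number a weaker inhibitor), compound 1 gives > 50000 nM, a limit of the assay.
Compound 2 `N#CC1=C(N)Oc2c(c3nc4ccccc4nc3c3ccccc23)C12C(=O)N(Cc1cnnn1-c1cc(Cl)ccc1Cl)c1ccccc12`: in this assay compound 2 gives > 50000 nM, likewise a limit.
Compound 3 `Cc1ccccc1-n1nncc1CN1C(=O)C2(C(C#N)=C(N)Oc3c(N)cc4nc5ccccc5nc4c32)c2ccccc21`: in this assay compound 3 gives > 50000 nM, again a limit.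

Compound 3 thus stands where every value here stands, at the limit of > 50000 nM in this assay, at which 3 of the 3 values shown sit. Compound 4 `N#CC1=C(N)Oc2c(N)cc3nc4ccccc4nc3c2C12C(=O)N(Cc1cnnn1-c1ccccc1Br)c1ccccc12` differs from compound 3 by bromo in place of methyl on an aromatic carbon. Going by the values given here, the only measured step, a step that the two limits leave unreadable from compound 1 to compound 2, runs between two limits and therefore has no readable size. Among the compounds with values here, no measured pair compares bromo with methyl. With every value sitting at the limit, compound 4 is expected to stay there as well, so the expected step that the limit leaves unreadable from compound 3 to compound 4 is none beyond the scatter. Compound 4 is accordingly estimated at 80000 nM, within 30000 nM to 300000 nM, most likely reported once more only as a limit.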

Compound 4, half-maximal inhibitory concentration: 38000 nM
For compound 4 the middle estimate is 2.1-fold (0.32 log units) above the measured one; measured number inside the range.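

In this assay, swapping methyl for bromo on this aromatic carbon yields the first readable number shown, not just another limit. The step reads an at least 1.3-fold lower number from compound 3 to compound 4 (0.11 log units; that floor lies within the scatter); compound 3 holds only a limit, so this is a floor, and the true size may be larger or may not exceed the usual scatter. Compound 4 remains a single readable case, with the other values at the limit: the limit of > 50000 nM in this assay, at which 3 of the 4 values shown sit.

From the compounds shown here alone, the true size of this step stays open. So does what a fluoro, a methoxy or an amine on this same carbon would give.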